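Acyl variation on the ring amine: acetyl, hydrogen, methylsulfonyl

A few compounds are considered here, and "the series" means these few. Any claim that something is new, unique, unknown or untested is made for them only; others in the source may bear on it.

Compound 1 `CC(=O)Nc1c(-c2ccccc2)oc2ccccc2c1=O` in a functional assay on KB cells (Homo sapiens) for cytotoxicity (on this read-out higher numbers stand for an effect only at larger amounts of compound and lower numbers for an effect already at smaller amounts), gives > 100 ug/mL, which is a limit of the assay and not a number.
Compound 2 `Nc1c(-c2ccccc2)oc2ccccc2c1=O` gives > 100 ug/mL in this assay, again a limit and not a number.

Among the compounds with values here, compound 2 therefore stands at the limit of this assay, with no number attached; (the limit of > 100 ug/mL in this assay, at which 2 of the 2 values shown sit), so no compound of the series has yet given a readable value. Within the data shown here, the only measured step, a step that the two limits leave unreadable from compound 1 to compound 2, is unreadable because both ends are limits. Compound 3 `CS(=O)(=O)Nc1c(-c2ccccc2)oc2ccccc2c1=O` carries methylsulfonyl in place of hydrogen on a nitrogen on an aromatic ring. The step from compound 2 to compound 3 is of the same kind as the measured one, an acyl group on the ring nitrogen in place of hydrogen, but that step gives no size and no direction, so there is nothing measured to set an expectation for compound 3 other than the limit itself. Compound 3 is expected to sit at or near that limit, as a step that the limit leaves unreadable from compound 2 to compound 3. The estimate for compound 3 is 150 ug/mL, with a range from 40 ug/mL to 500 ug/mL, and the assay is expected most likely to report only a limit again.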

Compound 3, concentration for half-maximal effect: 10 ug/mL
The estimate for compound 3 lay 15-fold (1.18 log units) above the measured number, and the stated range ends above it.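

Working notes on the ring nitrogen: in this assay, methylsulfonyl in place of hydrogen on a nitrogen on an aromatic ring gives an at least 10-fold lower number from compound 2 to compound 3 (1.00 log units; beyond the scatter), so this position can carry a change that moves the read-out into the measurable range. Methylsulfonyl in place of acetyl at the same place gives an at least 10-fold lower number from compound 1 to compound 3 (1.00 log units; beyond the scatter), which shows that the outcome depends on which group sits on this nitrogen and not merely on whether the hydrogen is replaced. Compound 3 is the only compound with a readable number, while the step between the other two cannot be read and the true size of both new steps stays unknown: the limit of > 100 ug/mL in this assay, at which 2 of the 3 values shown sit.

Going by these compounds, with a single sulfonyl example, it remains open whether the gain belongs to the methylsulfonyl group itself or extends to sulfonyl groups in general, such as ethylsulfonyl, phenylsulfonyl or one with a longer chain. On these data alone, it is also open how a urea or a benzoyl group on the same nitrogen would read in this assay, and whether any of these would fall further than compound 3 at 10 ug/mL.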